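Swapping the Sulfonyl Ring of Compound 3 for Difluorophenyl

A few compounds are considered here, and "the series" means these few. Any claim that something is new, unique, unknown or untested is made for them only; others in the source may bear on it.

In an assay on MDA-MB-231 cells for binding affinity to C-X-C chemokine receptor type 4 (Homo sapiens), read by fluorescence and microscopy, with stated times of 10 min and 30 min (on this read-out lower numbers stand for an effect already at smaller amounts and higher numbers for an effect only at larger amounts of compound), compound 3 `O=C(NCc1ccc(CNS(=O)(=O)c2ccc3c(c2)CCO3)cc1)c1ccc(F)cc1` gives 10 nM, the lowest number among the three measured compounds. Compound 1 `O=C(NCc1ccc(CNS(=O)(=O)c2ccc(Cl)cc2)cc1)c1ccc(F)cc1` gives 100 nM, and compound 2 `O=C(NCc1ccc(CNS(=O)(=O)c2cccc3ccccc23)cc1)c1ccc(F)cc1` gives 1000 nM. Compound 4 `O=C(NCc1ccc(CNS(=O)(=O)c2ccc(F)c(F)c2)cc1)c1ccc(F)cc1` has not yet been measured; it differs from compound 3 in one place: a group of 8 heavy atoms (6 carbon, 2 fluorine; one six-membered aromatic ring of carbon only) in place of a group of 9 heavy atoms (8 carbon, 1 oxygen; one five-membered non-aromatic ring with 1 hetero atom, one six-membered aromatic ring of carbon only), on a sulfonyl sulfur. Among the measured compounds shown here, the steps that bear on this change are a 10-fold lower number from compound 1 to compound 3 (1.00 log units; beyond the scatter) and a 100-fold lower number from compound 2 to compound 3 (2.00 log units; beyond the scatter), with a 10-fold higher number from compound 1 to compound 2 (1.00 log units; beyond the scatter) showing how much the group on the sulfonyl sulfur matters. The group entering in compound 4 is closer in make-up to that of compound 1 than to that of compound 2, so compound 4 is expected to show a 10-fold higher number from compound 3 to compound 4 (1.00 log units; beyond the scatter). The estimate for compound 4 is 100 nM, between 30 nM and 300 nM.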

Compound 4, effective concentration (reported as EC, without a stated level of effect): 10 nM
The estimate for compound 4 lay 10-fold (1.00 log units) above the measured number; the measured number lies below the stated range.
By their numbers in this assay, from the lowest: compounds 3 and 4 (each within the scatter of the next); then compound 1; then compound 2.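

In this assay, the oxygen-containing five-membered ring of compound 3 proves not to be required at this position on the sulfonyl sulfur, since 3,4-difluorophenyl, with no such ring, gives no change at the digits printed from compound 3 to compound 4 (within the scatter). The same group also gives a 10-fold lower number from compound 1 to compound 4 (1.00 log units; beyond the scatter) and a 100-fold lower number from compound 2 to compound 4 (2.00 log units; beyond the scatter), so a single six-membered aromatic ring can match compound 3 when it carries two fluorines. No measurement shown explains these differences. Still open, from the compounds shown here alone, is whether 4-fluorophenyl would keep this number, and whether a ring carrying an amine or a carboxylic acid would be tolerated here.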